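Removing a side chain from a lactone core

The compounds below may be only part of what the source reports. "The series", "measured", "known", "first", "only" and "open" are said of these compounds alone.

Compound 1 `CC(=O)CC[C@]1(C(C)=O)C(=O)O[C@@H](OC(C)=O)[C@H]1C` is tested in a functional assay on MCF7 cells (Homo sapiens) for cytotoxicity, read by MTT assay (a higher number here means a weaker inhibitor, a lower number a stronger inhibitor), where compound 1 gives 6000 nM. Among the three compounds measured, compound 1 has the second highest number: compound 2 `CC(=O)[C@@]1(C)C(=O)O[C@@H](OC(=O)C(C)(C)C)[C@H]1C` gives 3000 nM, which lies within the scatter of compound 1, while compound 3 `CC(=O)O[C@@H]1OC(=O)[C@@](Cc2ccccc2)(C(C)=O)[C@@H]1C` gives 51000 nM, clearly a higher number than compound 1. Compound 4 `CC(=O)O[C@@H]1OC(=O)[C@@H](C(C)=O)[C@@H]1C` has not yet been measured. It differs from compound 1 by hydrogen in place of 2-acetylethyl on a saturated ring carbon. Among the compounds with values here, no measured pair shows this exact change, so the step is expected to be modest and, if anything, toward a higher number, since the smaller compound loses part of its structure. The value for compound 4 is estimated at 10000 nM, with a range from 3000 nM to 40000 nM, which would mean a step of a 1.7-fold higher number from compound 1 to compound 4 (0.22 log units; within the scatter) in this assay.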

Compound 4, half-maximal inhibitory concentration: > 50000 nM
Compound 4 gave a limit, no number (the forecaster's own chance of this, stated with the estimate: 10%); at least 5.0-fold (0.69 log units) between middle value and limit.
By their numbers in this assay, from the lowest: compounds 2 and 1 (each within the scatter of the next); then compound 3.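

At this saturated ring carbon, hydrogen in place of 2-acetylethyl gives an at least 8.3-fold higher number from compound 1 to compound 4 (0.92 log units; beyond the scatter) in this assay, so the side chain cannot simply be dropped without loss of activity. Within the data shown here, this is the first change in the set made at a single place. Compound 4 gives a limit, not a number: the limit of > 50000 nM in this assay, at which 1 of the 4 values shown sits.

On these data alone, whether an ethyl group, a longer chain, an amine or a carboxylic acid at this carbon would restore activity stays open. Also open, as far as these compounds go, is whether the step depends on the chain of 2-acetylethyl or on its carbonyl.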